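Swapping an aryl tail for an ester on the core

A few compounds are considered here, and "the series" means these few. Any claim that something is new, unique, unknown or untested is made for them only; others in the source may bear on it.

Compound 1 `COc1ccc(-c2ccc(NC3=CC(=O)c4ncncc4C3=O)cc2)cc1` carries an aniline bearing a 4-methoxyphenyl group on the shared core. In a functional assay on MIA PaCa-2 cells (Homo sapiens) for cytotoxicity, read by MTT assay, with a stated time of 72 h (a lower number here means a stronger inhibitor, a higher number a weaker inhibitor), compound 1 gives 2100 nM. Among the three compounds measured so far, compound 1 stands with the second highest number. Compound 2 `COc1cccc(NC2=CC(=O)c3ncncc3C2=O)c1`, which carries a methoxy group directly on the aniline ring instead, gives 1800 nM in this assay, a number within the usual scatter of that of compound 1. The bare core, compound 3 `O=C1C=CC(=O)c2ncncc21`, gives 9400 nM, a higher number that lies beyond the scatter, so compound 1 gives the lower number of the two.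

Compound 4 `CCOC(=O)c1ccc(NC2=CC(=O)c3ncncc3C2=O)cc1` differs from compound 1 by ethoxycarbonyl in place of 4-methoxyphenyl on an aromatic carbon. Among the compounds with values here, no measured pair shows a change of this kind, so its size is unknown. Since compound 1 and compound 2 give similar numbers with different groups on the aniline ring, no step beyond the scatter is expected here. Compound 4 is therefore expected to give about 3000 nM, within 1200 nM to 7500 nM. That estimate amounts to an expected step of a 1.4-fold higher number from compound 1 to compound 4 (0.15 log units; within the scatter).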

Compound 4, half-maximal inhibitory concentration: 5500 nM
Compound 4: the middle estimate sits 1.8-fold (0.26 log units) below what was measured; the range from low to high includes it.
By their numbers in this assay, from the lowest: compounds 2 and 1 (each within the scatter of the next); then compounds 4 and 3 (each within the scatter of the next).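

In this assay, within the data shown here, putting ethoxycarbonyl in place of 4-methoxyphenyl gives a 2.6-fold higher number from compound 1 to compound 4 (0.42 log units; beyond the scatter) and is the first step here that can be read for a single change on the shared core. It shows that this aromatic carbon, para to a large group, is not indifferent to what it carries, something that compounds 1 and 2 could not show. Still, the change removes a ring and brings in a shorter group with no ring at once, so this one step cannot separate those two differences, and no measurement at hand explains it.

From the compounds shown here alone, whether a carboxylic acid, an amine or a longer ester at this place would bring the number down or push it up remains open. So does whether a different aryl group would behave like 4-methoxyphenyl.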